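Swapping fluoro for chloro on a vinyl sulfone series

The source may report more compounds than this note shows. Statements on the series, on what has been measured and on what is new or still open speak of the compounds shown alone.

Measured compounds:
Compound 1 `O=S(=O)(/C=C\c1ncccc1Cl)c1ccccc1F` gives 1030 nM in an assay on U2OS cells for activation of nuclear factor erythroid 2-related factor 2 (Homo sapiens), read by beta-arrestin recruitment, with a stated time of 6 h; on this read-out lower numbers stand for an effect already at smaller amounts and higher numbers for an effect only at larger amounts of compound.
Compound 2 `O=S(=O)(/C=C\c1ncccc1Cl)c1ccccc1Cl` gives 1100 nM in this assay.
Compound 3 `O=S(=O)(/C=C/c1ccncc1)c1cccc(F)c1` gives 950 nM in this assay.

Compound 1 and compound 2 share a core and differ in one place: chloro in place of fluoro on an aromatic carbon. That swap produced a 1.1-fold higher number from compound 1 to compound 2 (0.03 log units; within the scatter), so the two compounds behave alike in this test.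

Compound 3 has a different core; how the two cores differ is not broken down here. Its value sits close to those of compound 1 and compound 2, and all three lie within the usual scatter of one another, so none can be called stronger or weaker than the rest.

Compound 4 `O=S(=O)(/C=C/c1ccncc1)c1cccc(Cl)c1` has not yet been measured. It relates to compound 3 the way compound 2 relates to compound 1: chloro in place of fluoro on an aromatic carbon. This is the same kind of change, not the same one, since in compound 1 the place is ortho to a large group, whereas in compound 3 it is meta to a large group.

Within the data shown here, the step from compound 3 to compound 4 is expected to be small, because the one earlier example of this swap gave a 1.1-fold higher number from compound 1 to compound 2 (0.03 log units; within the scatter). This means an expected step of a 1.1-fold higher number from compound 3 to compound 4 (0.02 log units; within the scatter). Compound 4 is therefore estimated at 1000 nM. Among the measured compounds shown here, compound 4 is expected to fall between 500 nM and 2100 nM, with the wide range reflecting that only one prior example of this swap exists and that it sat at a different place.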

Compound 4, half-maximal effective concentration: 528 nM
Compound 4: the middle estimate sits 1.9-fold (0.28 log units) above what was measured, and the stated range covers the measured number.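

Replacing fluoro with chloro on an aromatic carbon of the core of compound 3 gave a 1.8-fold lower number from compound 3 to compound 4 (0.26 log units; within the scatter) in this assay, so this step cannot be told apart from the ordinary spread of repeated measurements. Set beside the earlier example of the same swap, the new step does not differ from it in any way these data can resolve: the same change on two cores in this assay, a 1.1-fold higher number (0.03 log units; within the scatter) from compound 1 to compound 2 and a 1.8-fold lower number (0.26 log units; within the scatter) from compound 3 to compound 4, 1.9-fold (0.28 log units) apart, within the scatter of two such steps. Among these compounds, this fits with the swap carrying over from one core to the other without a clear change in the number, but it does not show that the swap acts identically across the series, as there are only two pairs and the swap sits at a different place in each.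

The compounds shown carry only fluoro or chloro at the swapped places, which leaves open what a methyl group, a methoxy group, an amine or a carboxylic acid would do there. From the compounds shown here alone, all four values also come from this assay alone, so whether the swap behaves the same way on further cores or in any other test remains open.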